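This account rests on a few compounds, and the source may have more. Where it says the series, first, only, none or still open, it means among the compounds named here.

compound 1 `C[C@H](NC(=O)C1CCOCC1)c1ccc(NC(=O)[C@H]2C[C@@H]2c2cccnc2)cc1` gives 7 nM
compound 2 `COCC(=O)N[C@@H](C)c1ccc(NC(=O)[C@H]2C[C@@H]2c2cccnc2)cc1` gives 111 nM
compound 3 `C[C@H](NC(=O)c1ccc(F)cc1)c1ccc(NC(=O)[C@H]2C[C@@H]2c2cccnc2)cc1` gives 12 nM

All three values come from a functional assay on COR-L23 cells (Homo sapiens) for antiproliferative activity, read by CellTiter-Glo, with a stated time of 4 days (a lower number here means a stronger inhibitor, a higher number a weaker inhibitor), and the three compounds differ only in the group on the carbonyl carbon. Compound 3 lies close to compound 1 and well away from compound 2. The first gap is a 1.7-fold higher number from compound 1 to compound 3 (0.23 log units; within the scatter) and the second is a 9.3-fold lower number from compound 2 to compound 3 (0.97 log units; beyond the scatter) as measured.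

Compound 4 `C[C@H](NC(=O)c1ccc(C#N)cc1)c1ccc(NC(=O)[C@H]2C[C@@H]2c2cccnc2)cc1` changes compound 3 in one place: cyano in place of fluoro on an aromatic carbon on a six-membered aromatic ring of carbon only, para to a large group. Within the data shown here, no measured step covers this swap of cyano for fluoro, so the evidence is indirect. Changes of the whole group on the same carbonyl carbon span a wide range. The change to compound 2 is large, at a 16-fold higher number from compound 1 to compound 2 (1.20 log units; beyond the scatter) in the same read-out, while the step to compound 3 stays within the scatter. The present change keeps the phenyl group and replaces only its fluoro, so a small effect seems the likeliest outcome, though the data cannot rule out a larger one.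

The expected result is a 1.3-fold higher number from compound 3 to compound 4 (0.10 log units; within the scatter) in this assay and this is read as no step beyond the scatter. Compound 4 is estimated at 15 nM with an expected range from 6 nM to 40 nM as the likely outcome.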

Compound 4, half-maximal inhibitory concentration: 19 nM
Compound 4: the middle estimate sits 1.3-fold (0.10 log units) below what was measured; low and high end bracket the measured number.
By their numbers in this assay, from the lowest: compounds 1, 3 and 4 (each within the scatter of the next, the first and the last beyond it); then compound 2.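

In this assay, among these compounds, the swap of cyano for fluoro on the aromatic carbon para to a large group gives a 1.6-fold higher number from compound 3 to compound 4 (0.20 log units; within the scatter), the first direct reading at this place, and it shows that a nitrile, with its counted hydrogen-bond acceptor and extra heavy atom, can replace fluoro without a step beyond the scatter. The wider comparisons sharpen the picture: 4-cyanophenyl retains a clear advantage over methoxymethyl, with a 5.8-fold lower number from compound 2 to compound 4 (0.77 log units; beyond the scatter), but against oxan-4-yl it gives a 2.7-fold higher number from compound 1 to compound 4 (0.43 log units; beyond the scatter), a gap beyond the scatter that 4-fluorophenyl did not show, even though the step between the two aryl groups themselves stays within it. No supporting measurement bears on this result, so the data offer no explanation for it.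

As far as these compounds go, whether an amine, a carboxylic acid or a methoxy group would be accepted in place of fluoro at this same aromatic carbon remains open. Also open, from the compounds shown here alone, is how piperidin-4-yl in place of oxan-4-yl, or a longer ether chain in place of methoxymethyl, would read on the same carbonyl carbon.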